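This account rests on a few compounds, and the source may have more. Where it says the series, first, only, none or still open, it means among the compounds named here.

Measured in an ADME assay on S9 fraction from liver (Rattus norvegicus) for metabolic stability, read by LC-MS, using NADPH, with a stated time of 60 min, tested at 10 uM; on this read-out lower numbers stand for a less stable compound and higher numbers for a more stable compound:

- compound 1 `C[C@H](O)Cc1cc(-c2ccnc3[nH]nc(C(F)(F)F)c23)cc(C2(C#N)CC2)c1`: 37%
- compound 2 `CC(=O)OCCc1cc(-c2ccnc3[nH]nc(C(F)(F)F)c23)cc(C2(C#N)CC2)c1`: 5%
- compound 3 `N#CC1(c2cc(CC(=O)O)cc(-c3ccnc4[nH]nc(C(F)(F)F)c34)c2)CC1`: 95%

Compound 3 stands highest of these three, and its distance to each of the others is beyond the scatter. The next compound to be tested is compound 4 `N#CC1(c2cc(CCF)cc(-c3ccnc4[nH]nc(C(F)(F)F)c34)c2)CC1`. It has fluoromethyl in place of the carboxy of compound 3, on a saturated chain carbon bound to an aromatic carbon (fluoromethyl in place of carboxy on a saturated chain carbon bound to an aromatic carbon). Cut one bond further out, the same difference reads carboxymethyl to 2-fluoroethyl.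

Two measured steps end at the carboxy group of compound 3, and both are large: a number 58 percentage points higher from compound 1 to compound 3 (beyond the scatter), and a number 90 percentage points higher from compound 2 to compound 3 (beyond the scatter). The step of a number 32 percentage points lower from compound 1 to compound 2 (beyond the scatter) shows that the compounds without carboxy also differ widely from each other. Compound 4 has no carboxy either, so it is expected to fall well short of compound 3, somewhere near the span of the two compounds without that group. Among the measured compounds shown here, no measured compound carries fluoromethyl at this place, so the range must stay wide.

A large downward move is therefore expected, a number 55 percentage points lower from compound 3 to compound 4 (beyond the scatter). For compound 4 the estimated value is 40%, with an expected range from 15% to 70%.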

Compound 4, percent of the compound remaining: 67%
Beside the measured number, compound 4's estimate is 27 percentage points below it; the measured number falls inside the stated range.
By their numbers in this assay, from the lowest: compound 2; then compound 1; then compound 4; then compound 3.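

In this assay, putting fluoromethyl where compound 3 has carboxy gives a number 28 percentage points lower from compound 3 to compound 4 (beyond the scatter), so this change loses ground but leaves compound 4 second of the four. Compared with the two other compounds without carboxy, the result is a clear gain: a number 30 percentage points higher from compound 1 to compound 4 (beyond the scatter), and a number 62 percentage points higher from compound 2 to compound 4 (beyond the scatter). A high number at this place therefore does not depend on carboxy alone, and the small fluoromethyl group, with 0 hydrogen-bond donors and 0 hydrogen-bond acceptors, reaches well past the 1-hydroxyethyl and acetoxymethyl groups of the other compounds without carboxy.

Nothing at hand gives a measured reason for any of these differences. Going by these compounds, it remains open whether an amine, or a longer chain ending in fluorine, at this same place would come closer to compound 3 or fall back towards compound 1 and compound 2.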